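From 2-chloro-4-nitrophenyl to amino on an amine nitrogen

The source may report more compounds than this note shows. Statements on the series, on what has been measured and on what is new or still open speak of the compounds shown alone.

Of the compounds shown here, three sharing one core have been measured in a functional assay on A-431 cells (Homo sapiens) for inhibition, read by sulforhodamine B assay, with a stated time of 2 days; a lower number here means a stronger inhibitor of growth, a higher number a weaker inhibitor of growth. Compound 1 `CC1=C(C(=O)Nc2cccc([N+](=O)[O-])c2)C(c2ccc(O)cc2O)NC(SCc2ccccc2)=N1` gives > 100000 nM, which is a limit of the assay. Compound 2 `CC1=C(C(=O)Nc2cccc([N+](=O)[O-])c2)C(c2ccc(O)cc2O)NC(NCc2ccccc2)=N1` gives 35600 nM. Compound 3 `CC1=C(C(=O)Nc2cccc([N+](=O)[O-])c2)C(c2ccc(O)cc2O)NC(Nc2ccc([N+](=O)[O-])cc2Cl)=N1` gives 3940 nM, the lowest number of the three, which makes it the strongest inhibitor of growth among them.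

Compound 4 `CC1=C(C(=O)Nc2cccc([N+](=O)[O-])c2)C(c2ccc(O)cc2O)NC(NN)=N1` has yet to be measured in this assay. It differs from compound 3 by amino in place of 2-chloro-4-nitrophenyl on an amine nitrogen.

Among the compounds with values here, three measured steps bear on this change. The closest is the swap of benzyl for 2-chloro-4-nitrophenyl on an amine nitrogen, which gave a 9.0-fold lower number from compound 2 to compound 3 (0.96 log units; beyond the scatter). Against benzylsulfanyl, the (2-chloro-4-nitrophenyl)amino group gave an at least 25-fold lower number from compound 1 to compound 3 (1.40 log units; beyond the scatter), while benzylamino gave an at least 2.8-fold lower number from compound 1 to compound 2 (0.44 log units; beyond the scatter). Within the data shown here, no measured compound carries the small amino group at this place, so the guidance is indirect. Compound 4 loses the group that brought the gain seen in compound 3 at 3940 nM, so a modest move towards a higher number is expected. The expected change is a 5.1-fold higher number from compound 3 to compound 4 (0.71 log units; beyond the scatter). Compound 4 is estimated at 20000 nM, with an expected range from 5000 nM to 80000 nM.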

Compound 4, concentration for 50% growth inhibition: 24300 nM
Beside the measured number, compound 4's estimate is 1.2-fold (0.08 log units) below it; the measured number falls inside the stated range.
By their numbers in this assay, from the lowest: compound 3; then compounds 4 and 2 (each within the scatter of the next). At a limit, above all of these: compound 1.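

In this assay, the new result shows that this amine nitrogen does not tolerate every change equally: a 6.2-fold higher number from compound 3 to compound 4 (0.79 log units; beyond the scatter), so the smallest group tested gives up much of what the 2-chloro-4-nitrophenyl group had gained. Within the data shown here, the comparison with benzyl adds what the earlier compounds could not show, a 1.5-fold lower number from compound 2 to compound 4 (0.17 log units; within the scatter), so amino and benzyl are not told apart here and, among the three groups on this nitrogen, only 2-chloro-4-nitrophenyl stands clear of the others. At the carbon with a double bond to nitrogen, aminoamino joins the other two nitrogen-linked groups in reading lower than benzylsulfanyl, an at least 4.1-fold lower number from compound 1 to compound 4 (0.61 log units; beyond the scatter), though this step has no upper end, as compound 1 stands at a limit of the assay: the limit of > 100000 nM in this assay, at which 1 of the 4 values shown sits.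

The compounds shown leave open which part of the 2-chloro-4-nitrophenyl group carries the difference, which a plain phenyl, a 2-chlorophenyl or a 4-nitrophenyl on the same nitrogen would begin to separate. They also leave open how a methyl or a longer alkyl chain would read at this place.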